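The source may report more compounds than this note shows. Statements on the series, on what has been measured and on what is new or still open speak of the compounds shown alone.

Compound 1 `Cc1ccc(-c2nc(N)c3cc(CN4CCCC4)sc3n2)o1` is a thienopyrimidine-type amine carrying a 5-methylfuran-2-yl group and a pyrrolidin-1-ylmethyl arm. Going by the values given here, in an assay on CHO-K1 cells for antagonist activity at adenosine receptor A1 (Homo sapiens), read by a beta-galactosidase reporter, with stated times of 15 min and 6 h (on this read-out higher numbers stand for weaker inhibition and lower numbers for stronger inhibition), compound 1 gives 620 nM, the highest of the two numbers measured here, though its only neighbour, compound 2 `Cc1ccc(-c2nc(N)c3cc(CN4CCCCC4)sc3n2)o1`, with 610 nM in this assay, stands within the scatter of it: a 1.0-fold lower number from compound 1 to compound 2 (0.01 log units; within the scatter).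

The compound of interest, compound 3 `N#Cc1cccc(-c2nc(N)c3cc(CN4CCCC4)sc3n2)c1`, keeps the pyrrolidin-1-ylmethyl arm of compound 1 and differs from it only in the aryl group: 3-cyanophenyl in place of 5-methylfuran-2-yl on an aromatic carbon. Among the compounds with values here, the single measured step, from compound 1 to compound 2, alters the saturated amine ring and leaves the aryl group untouched, so it does not bear on this exchange. Within the data shown here, no measured pair here varies the aryl group at all, and the direction and size of the step are therefore unknown from the data.

In the absence of a comparable step, compound 3 is expected to lie near compound 1, at an estimated 800 nM in this assay, with a wide range from 150 nM to 4000 nM, which corresponds to an expected step of a 1.3-fold higher number from compound 1 to compound 3 (0.11 log units; within the scatter).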

Compound 3, inhibition constant: 130 nM
Compound 3: middle estimate off by 6.2-fold (0.79 log units), on the high side; the whole stated range lies above it.
By their numbers in this assay, from the lowest: compound 3; then compounds 2 and 1 (each within the scatter of the next).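

At the aromatic carbon between two ring nitrogen atoms, the exchange of 5-methylfuran-2-yl for 3-cyanophenyl gives a 4.8-fold lower number from compound 1 to compound 3 (0.68 log units; beyond the scatter) in this assay. Going by these compounds alone, this is the first step here to lie beyond the scatter, whereas the change in the saturated amine ring gave a 1.0-fold lower number from compound 1 to compound 2 (0.01 log units; within the scatter), so the aryl group matters more in this small set than the amine ring. The two groups have the same counts of hydrogen-bond donors and acceptors and differ in ring type, heavy-atom count and the triple bond, but no measurement shown here accounts for the step.

The compounds shown cannot separate the part played by the six-membered carbon ring from that of the nitrile, which a plain phenyl group would address, as would a 3-methoxyphenyl or 3-carboxyphenyl group in the same place. Going by these compounds, it also remains open whether the step carries over to the piperidin-1-yl arm of compound 2, and whether an amine or a longer chain on the aryl ring would take the number further in either direction.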